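This account rests on a few compounds, and the source may have more. Where it says the series, first, only, none or still open, it means among the compounds named here.

Compound 2 `NS(=O)(=O)c1ccc(N/N=C(/S)NC(c2ccccc2)c2ccccc2)c([N+](=O)[O-])c1` is the strongest binder among the numbers shown in an assay on cell membranes for inhibition of B2 bradykinin receptor (Rattus norvegicus); a higher number here means a weaker inhibitor, a lower number a stronger inhibitor. Compound 2 gives 4 nM. Compound 3 `O=[N+]([O-])c1cc(S(=O)(=O)NCc2ccco2)ccc1N/N=C(/S)NCc1ccco1`, which carries a different group in place of the plain sulfamoyl and a different chain on the thiosemicarbazide, gives in this assay a value of 540 nM, a higher number beyond the usual scatter. Compound 1 `O=[N+]([O-])c1cc(S(=O)(=O)NCc2ccccc2)ccc1N/N=C(\S)CCc1ccccc1` shows in this assay only a limit of the assay, > 100000 nM, not a measured number (the limit of > 100000 nM in this assay, at which 1 of the 3 values shown sits).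

Compound 4 `O=[N+]([O-])c1ccccc1N/N=C(/S)NC(c1ccccc1)c1ccccc1` has not yet been measured. It differs from compound 2 in one place: hydrogen in place of sulfamoyl on an aromatic carbon. The sulfamoyl leaves and a hydrogen enters.

No step between measured compounds isolates this change, so the expectation rests on the fact that compound 2, the only compound with the plain sulfamoyl, gives the lowest number shown. The removal is expected to weaken binding by a clear margin, beyond the scatter. The step of a 15-fold higher number from compound 2 to compound 4 (1.18 log units; beyond the scatter) is estimated as a loss. For compound 4 the expected value in this assay is 60 nM, within a range from 8 nM to 500 nM.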

Compound 4, inhibition constant: 38 nM
The estimate for compound 4 lay 1.6-fold (0.20 log units) above the measured number; measured number inside the range.
By their numbers in this assay, from the lowest: compound 2; then compound 4; then compound 3. At a limit, above all of these: compound 1.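

Among the compounds shown here, this is the first direct look at the sulfamoyl group on this aromatic carbon, para to the large group and meta to the nitro group: in this assay, replacing it with hydrogen gives a 9.5-fold higher number from compound 2 to compound 4 (0.98 log units; beyond the scatter). For the compounds shown here, the sulfamoyl therefore adds to binding, a gain that the earlier compounds could not isolate because each of them also differs in its chain on the thiosemicarbazide. It is not essential, however, since compound 4, which lacks it, still gives 38 nM.

The compounds shown leave open whether a carboxylic acid or an amine on this same carbon would match the sulfamoyl of compound 2 or fall closer to the hydrogen of compound 4. Nothing shown here bears on why the loss occurs.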